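The source may report more compounds than this note shows. Statements on the series, on what has been measured and on what is new or still open speak of the compounds shown alone.

Compound 1 `Cc1nc(N)c2c(-c3ccccc3)cn([C@@H]3O[C@H](CO)[C@@H](O)[C@H]3O)c2n1`: in a functional assay on HeLa S3 cells (Homo sapiens) for antiproliferative activity, read by XTT assay, with a stated time of 72 h (a higher number here means a weaker inhibitor, a lower number a stronger inhibitor), compound 1 gives only a limit, > 20000 nM.
Compound 2 `O=c1[nH]cnc2c1c(-c1cc3ccccc3o1)cn2[C@@H]1O[C@H](CO)[C@@H](O)[C@H]1O`: in this assay compound 2 gives only a limit, > 20000 nM.
Compound 3 `Cc1nc(N)c2c(-c3cc4ccccc4o3)cn([C@@H]3O[C@H](CO)[C@@H](O)[C@H]3O)c2n1`: in this assay compound 3 gives only a limit, > 20000 nM.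

Compound 3 and compound 1 share one core and differ by phenyl in place of 1-benzofuran-2-yl on an aromatic carbon. Because both values sit at the limit of > 20000 nM in this assay, at which 3 of the 3 values shown sit, the step that the two limits leave unreadable from compound 3 to compound 1 cannot be read. Compound 2 carries a different core; how the two cores differ is not broken down here. The unmeasured compound 4 `O=c1[nH]cnc2c1c(-c1ccccc1)cn2[C@@H]1O[C@H](CO)[C@@H](O)[C@H]1O` relates to compound 2 through (phenyl in place of 1-benzofuran-2-yl on an aromatic carbon), the same change as that from compound 3 to compound 1, made at the same place. Going by the values given here, nothing among the measured compounds shows this change shifting potency out of the limit region, so compound 4 is expected to stay there too. The step that the limit leaves unreadable from compound 2 to compound 4 is therefore estimated as essentially flat, resting on compound 2 at > 20000 nM. For compound 4 the expected value in this assay is 30000 nM, between 10000 nM and 100000 nM.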

Compound 4, half-maximal inhibitory concentration: > 20000 nM
Compound 4 was reported as a limit (the forecaster's own chance of this, stated with the estimate: 85%); the middle value lies beyond the limit too.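

In this assay compound 4 also gives only a limit, > 20000 nM. The step from compound 2 to compound 4 therefore cannot be read, because both compounds sit at the same limit: the limit of > 20000 nM in this assay, at which 4 of the 4 values shown sit.

The compounds shown leave open whether phenyl and 1-benzofuran-2-yl differ in potency at all, and what true potency any of the four compounds has.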